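Inverting One Stereocentre in a Weak Antiproliferative Lactone

The source may hold more compounds than are shown below. What is called first, only, known or untested is meant among the compounds shown, and "the series" means these compounds.

Compound 1, `COc1ccc(/C=C/[C@H]2CC=CC(=O)O2)cc1`, in a functional assay on A549 cells (Homo sapiens) for antiproliferative activity, read by luminescence and CellTiter-Glo, with a stated time of 48 h (a higher number here means a weaker inhibitor, a lower number a stronger inhibitor), gives > 100000 nM.
Compound 2, `O=C1C=CC[C@@H](/C=C/C2CCCCC2)O1`, in this assay gives 68600 nM.
Compound 3, `O=C1C=CC[C@@H](/C=C/c2ccc(F)cc2)O1`, in this assay gives > 100000 nM.

The three compounds share a core and differ in what stands beyond the alkene. For compound 1 the result in this assay is a limit of the assay and not a number. For compound 3 the result in this assay is likewise a limit of the assay and not a number. Within the data shown here, compound 2 is therefore the only compound of the three with a numeric value in this assay; it stands as a weak inhibitor, while the other two sit at the limit of > 100000 nM in this assay, at which 2 of the 3 values shown sit.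

Compound 4, `O=C1C=CC[C@H](/C=C/C2CCCCC2)O1`, has not been measured in this assay. Its relation to compound 2 is the two compounds have the same atoms and bonds and differ only in configuration as drawn: 1 of 2 stereo elements differ; a stereocentre at a saturated ring carbon is drawn S in compound 2 and R in compound 4. No step between measured compounds is known in this set, so nothing shown speaks to what such an inversion does here. The expectation is a step of a 1.5-fold higher number from compound 2 to compound 4 (0.16 log units; within the scatter) toward weaker inhibition, with a fair chance that only a limit is reported, because compound 2 itself sits close to the limit of the limit of > 100000 nM in this assay, at which 2 of the 3 values shown sit. Compound 4 is estimated at 100000 nM, in the range from 30000 nM to 300000 nM.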

Compound 4, half-maximal inhibitory concentration: 31000 nM
Estimate against measurement, compound 4: 3.2-fold (0.51 log units) above, within the range that was stated.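

Among these compounds, the inversion gives the first step that can be read in this set: in this assay, changing the stereocentre at a saturated ring carbon from S to R gives a 2.2-fold lower number from compound 2 to compound 4 (0.34 log units; beyond the scatter). With the group beyond the alkene held constant, this step can be assigned to the configuration alone because no atom or bond changes: the fact that compounds 2 and 4 differ only in the configuration as drawn The earlier compounds could not show this, since compound 1 and compound 3 each rest on a limit of the assay and offer no number from which to measure a step: the limit of > 100000 nM in this assay, at which 2 of the 4 values shown sit.

The compounds shown leave open whether the same inversion would move the result in the same direction with the groups that stand beyond the alkene in compound 1 and compound 3, and a single pair cannot say whether the R configuration is generally favoured here. They also leave open how the R configuration of compound 4 would fare with a longer chain or an amine in place of the group it carries beyond the alkene.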